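Pyrimidinyl for Phenyl at the Ring Nitrogen

This account rests on a few compounds, and the source may have more. Where it says the series, first, only, none or still open, it means among the compounds named here.

Of the compounds shown here, three sharing one core have been measured in a functional assay on A549 cells (Homo sapiens) for antiproliferative activity, read by MTT assay, with a stated time of 72 h; on this read-out higher numbers stand for weaker inhibition and lower numbers for stronger inhibition. Compound 1 `Nc1nc(N)c2cc(CSC(=S)N3CCN(C4CCCCC4)CC3)ccc2n1` gives 4710 nM, compound 2 `Nc1nc(N)c2cc(CSC(=S)N3CCN(c4ccccc4)CC3)ccc2n1` gives 2970 nM, and compound 3 `Nc1nc(N)c2cc(CSC(=S)N3CCN(c4ccccc4[N+](=O)[O-])CC3)ccc2n1` gives 4360 nM. Compound 2 carries the lowest of the three numbers, yet every step connecting it to the others stays within the scatter: a 1.6-fold lower number from compound 1 to compound 2 (0.20 log units; within the scatter) and a 1.5-fold higher number from compound 2 to compound 3 (0.17 log units; within the scatter), while the remaining pair shows a 1.1-fold lower number from compound 1 to compound 3 (0.03 log units; within the scatter). For the measured compounds named here, no compound can therefore be singled out as more or less potent than another on these numbers.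

Compound 4 `Nc1nc(N)c2cc(CSC(=S)N3CCN(c4ncccn4)CC3)ccc2n1` is the next member. Relative to compound 2 the change is pyrimidin-2-yl in place of phenyl on an amine nitrogen in a ring, sitting on an amine nitrogen in a ring of a six-membered non-aromatic ring with 2 nitrogen. Going by the values given here, the steps that bear on this position are the exchange of cyclohexyl for phenyl, a 1.6-fold lower number from compound 1 to compound 2 (0.20 log units; within the scatter), and the addition of nitro to that phenyl, a 1.5-fold higher number from compound 2 to compound 3 (0.17 log units; within the scatter); neither moved the number beyond the scatter. The account therefore expects compound 4 to show no step beyond the scatter in this assay, a 1.2-fold higher number from compound 2 to compound 4 (0.07 log units; within the scatter). Compound 4 is estimated at 3500 nM, expected to fall between 1500 nM and 8000 nM.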

Compound 4, half-maximal inhibitory concentration: 4010 nM
For compound 4 the middle estimate is 1.1-fold (0.06 log units) below the measured one, within the range that was stated.
By their numbers in this assay, from the lowest: compounds 2, 4, 3 and 1 (each within the scatter of the next).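

The earlier steps shown here at this amine nitrogen in a ring changed only carbon-only rings or added nitro to one of them, whereas pyrimidin-2-yl places nitrogen in the aromatic ring itself and brings hydrogen-bond acceptors that phenyl lacks. Even so, the number in this assay stays within the scatter, both for the exchange of phenyl (a 1.4-fold higher number from compound 2 to compound 4 (0.13 log units; within the scatter)) and against the other two groups at this position (a 1.1-fold lower number from compound 3 to compound 4 (0.04 log units; within the scatter); a 1.2-fold lower number from compound 1 to compound 4 (0.07 log units; within the scatter)), so that cyclohexyl, phenyl, 2-nitrophenyl and pyrimidin-2-yl cannot be told apart here, with no compound of the four going against this. No accompanying measurement offers any account of this result.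

Still open, on these data alone, is whether a group of another kind on this nitrogen, such as an aliphatic amine or a carboxylic acid, would give a step beyond the scatter. It is equally open whether a longer chain joining this nitrogen to the phenyl or pyrimidin-2-yl ring would do so, since every aromatic ring shown here sits directly on the nitrogen.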